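Adding a Second Chloro to the Aryl Ring of Compound 1

The source may report more compounds than this note shows. Statements on the series, on what has been measured and on what is new or still open speak of the compounds shown alone.

Among the measured compounds shown here, compound 1 `O=CN1CCN(c2ccc(Cl)cc2)C1=S` gives 15600 nM in a functional assay on OVCAR-8 cells (Homo sapiens) for inhibition, read by sulforhodamine B assay, with a stated time of 48 h (on this read-out lower numbers stand for stronger inhibition of growth and higher numbers for weaker inhibition of growth), the lowest of the two numbers measured so far, yet compound 2 `N#C/C(=C\N1CCN(C(=O)c2ccco2)C1=S)C(=O)Nc1ccc(Cl)cc1` gives 20600 nM, which lies within the scatter of compound 1, so no real separation between the two can be claimed. Compound 3 `O=CN1CCN(c2ccc(Cl)c(Cl)c2)C1=S` has not yet been measured. It differs from compound 1 by chloro in place of hydrogen on an aromatic carbon. For the measured compounds named here, no step between measured compounds is available to gauge this change, and the expected step of a 1.4-fold lower number from compound 1 to compound 3 (0.15 log units; within the scatter) is small, hardly beyond the scatter. Compound 3 is therefore estimated to give 11000 nM in this assay, within 4500 nM to 28000 nM.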

Compound 3, concentration for 50% growth inhibition: 15000 nM
Estimate against measurement, compound 3: 1.4-fold (0.13 log units) below, within the range that was stated.
By their numbers in this assay, from the lowest: compounds 3, 1 and 2 (each within the scatter of the next).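

In this assay, chloro in place of hydrogen on the aromatic carbon ortho to a chloro group gives a 1.0-fold lower number from compound 1 to compound 3 (0.02 log units; within the scatter) and so separates the two compounds by no readable margin. Among the compounds shown here, this is the first step between measured compounds that differ in one place, and it shows that a second chloro at this position leaves growth inhibition within the scatter of compound 1. Nothing available gives a reason for this result. On these data alone, whether an amine or a carboxylic acid on this same carbon would also stay within the scatter remains open.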